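The source may hold more compounds than are shown below. What is called first, only, known or untested is meant among the compounds shown, and "the series" means these compounds.

Compound 1 `O=C(O)CCCSCCN1C(=O)CC[C@@H]1/C=C/[C@@H](O)Cc1cccc(N2Cc3ccccc3C2)c1`, compound 2 `O=C(O)CCCSCCN1C(=O)CC[C@@H]1/C=C/[C@@H](O)Cc1cccc(-c2cc3ccccc3o2)c1` and compound 3 `O=C(O)c1csc(SCCN2C(=O)CC[C@@H]2/C=C/[C@@H](O)Cc2cccc(-c3nc4ccccc4o3)c2)n1` share one core and differ only in the bicyclic group attached to an aromatic carbon. In an assay on CHO cells for displacement of a labelled ligand from prostaglandin E2 receptor EP3 subtype (Mus musculus), read by scintillation counting, with a stated time of 60 min (a lower number here means a stronger inhibitor, a higher number a weaker inhibitor), compound 1 returns only the limit > 10000 nM. Compound 2 likewise returns only the limit > 10000 nM in this assay. Compound 3 also returns only the limit > 10000 nM in this assay. The step that the two limits leave unreadable from compound 1 to compound 2 is accordingly unreadable in size. Within the data shown here, every value so far sits at the limit of > 10000 nM in this assay, at which 3 of the 3 values shown sit, so compound 3 stands at the same limit as the other two and no order among the three can be drawn.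

Compound 4 `Cc1cc(C)c2oc(-c3cccc(C[C@H](O)/C=C/[C@H]4CCC(=O)N4CCSc4nc(C(=O)O)cs4)c3)nc2c1` differs from compound 3 by 5,7-dimethyl-1,3-benzoxazol-2-yl in place of 1,3-benzoxazol-2-yl on an aromatic carbon. Among the measured compounds shown here, no measured step concerns methyl groups on this bicyclic ring, and none of the measured steps is readable in size, so nothing supports a move of compound 4 away from the limit. Compound 4 is therefore estimated at 15000 nM, with the expected range running from 4000 nM to 60000 nM. The step that the limit leaves unreadable from compound 3 to compound 4 is expected to be none beyond the scatter.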

Compound 4, inhibition constant: > 10000 nM
Compound 4: a limit, no number (the forecaster's own chance of this, stated with the estimate: 80%); the middle value is on the limit's open side.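

Among these compounds, compound 4 gives > 10000 nM, which is a limit and not a number, so no step from compound 3 to compound 4 can be read. The compounds shown leave open whether any bicyclic group on the shared core gives a readable value in this assay.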